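The compounds below may be only part of what the source reports. "The series", "measured", "known", "first", "only" and "open" are said of these compounds alone.

Measured so far:
- compound 1, `Cc1cc(C)cc(NC(=O)COc2cc(C)nc3ccc(C)cc23)c1`: 83000 nM
- compound 2, `COc1ccc2nc(C)cc(NCC(=O)Nc3cc(C)cc(C)c3)c2c1`: 204000 nM
- compound 3, `COc1ccc2nc(C)cc(OCC(=O)Nc3ccccc3)c2c1`: 63000 nM

In a physicochemical assay for solubility, in phosphate buffer, measured as kinetic solubility, with a stated time of 1 h, at pH 7.4 (on this read-out lower numbers stand for lower solubility and higher numbers for higher solubility), compound 3 gives the lowest of the three numbers. Compound 1 stands within the scatter of it, so the two cannot be told apart, while compound 2 gives a number that is beyond the scatter above compound 3.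

Compound 4, `COc1ccc2nc(C)cc(OCC(=O)NNC(=O)c3ccncc3)c2c1`, is not yet measured in this assay. Compared with compound 3 it carries ((pyridin-4-yl)carbonyl)amino in place of phenyl on an amide-type nitrogen. The group that enters brings a hydrogen-bond donor and two acceptors where the phenyl had none. For compound 4 the expected step is a 2.4-fold higher number from compound 3 to compound 4 (0.38 log units; beyond the scatter), an increase beyond the scatter. Compound 4 is therefore estimated at 150000 nM, within a range from 50000 nM to 400000 nM.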

Compound 4, solubility: >= 375000 nM
Compound 4: a limit, no number; the forecaster's own chance of this, stated with the estimate: 5%; at least 2.5-fold (0.39 log units) between middle value and limit.
By their numbers in this assay, from the lowest: compounds 3 and 1 (each within the scatter of the next); then compound 2. At a limit, above all of these: compound 4.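

In this assay, among the compounds shown here, ((pyridin-4-yl)carbonyl)amino in place of phenyl on an amide-type nitrogen gives the first step that can be read at this position: an at least 5.9-fold higher number from compound 3 to compound 4 (0.77 log units; beyond the scatter). Compound 4 gives >= 375000 nM, which is a limit of the assay and not a number, so this step shows only the smallest possible size of the change, not its full size.

The compounds shown do not separate the part played by the pyridin-4-yl ring from that of the carbonyl and amino link. Benzoylamino, or pyridin-4-yl alone, on this nitrogen would be needed to pull the two apart.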